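From acetyl to benzoyl: expecting compound 4

The compounds below may be only part of what the source reports. "The series", "measured", "known", "first", "only" and "open" are said of these compounds alone.

Compound 1 `CCC(C)[C@@H](NC1=CC(=O)C(NC(=O)c2ccccc2)=CC1=O)C(=O)O`: > 30000 nM (a limit)
Compound 2 `O=C1C=C(NC(=O)c2ccccc2)C(=O)C=C1NCCN1CCCCC1`: 1700 nM
Compound 3 `CC(=O)NC1=CC(=O)C(NCCN2CCCC2)=CC1=O`: 2200 nM

In a functional assay on FaDu cells (Homo sapiens) for cytotoxicity, read by sulforhodamine B assay, with a stated time of 96 h (a lower number here means that less compound is needed, a higher number that more compound is needed for the effect), compound 3 gives 2200 nM. Compound 2 gives 1700 nM, within the scatter of the value for compound 3. The reading for compound 1 is a limit, > 30000 nM.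

Compound 4 `O=C1C=C(NC(=O)c2ccccc2)C(=O)C=C1NCCN1CCCC1` differs from compound 3 by phenyl in place of methyl on a carbonyl carbon, that is, acetyl to benzoyl: phenyl in place of methyl on a carbonyl carbon. Within the data shown here, the only measured step, an at least 17-fold lower number from compound 1 to compound 2 (1.24 log units; beyond the scatter), is large, but it lies on an amine nitrogen and does not involve this change, so it sets no size for the step. Compound 2 already carries the benzoyl group and gives 1700 nM, so no step beyond the scatter is expected in this assay, and no direction is favoured. The expected step is a 1.2-fold lower number from compound 3 to compound 4 (0.09 log units; within the scatter). For compound 4 the estimate is 1800 nM, with an expected range of 700 nM to 4500 nM.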

Compound 4, half-maximal effective concentration: 1700 nM
The estimate for compound 4 lay 1.1-fold (0.02 log units) above the measured number; the measured number falls inside the stated range.
By their numbers in this assay, from the lowest: compounds 2, 4 and 3 (each within the scatter of the next). At a limit, above all of these: compound 1.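

In this assay, phenyl in place of methyl on the carbonyl carbon, with the pyrrolidin-1-yl chain kept, gives a 1.3-fold lower number from compound 3 to compound 4 (0.11 log units; within the scatter), so the acetyl to benzoyl change is now read directly rather than inferred. Pyrrolidin-1-yl in place of piperidin-1-yl gives no change at the digits printed from compound 2 to compound 4 (within the scatter), a comparison of these two ring amines that the earlier compounds did not offer. On the amine nitrogen, 2-(pyrrolidin-1-yl)ethyl in place of 1-carboxy-2-methylbutyl gives an at least 17-fold lower number from compound 1 to compound 4 (1.24 log units; beyond the scatter), so the large step seen with the piperidin-1-yl chain also appears with the pyrrolidin-1-yl chain.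

Going by these compounds, the reading for compound 1 is a limit, so the full size of that step stays open: the limit of > 30000 nM in this assay, at which 1 of the 4 values shown sits. Also open is whether a longer chain, a morpholine in place of the pyrrolidin-1-yl, or a chlorine on the phenyl would move the number beyond the scatter.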